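Swapping Chloro for Bromo on a Shared Inactive Core

This account rests on a few compounds, and the source may have more. Where it says the series, first, only, none or still open, it means among the compounds named here.

Compound 1 `CCCCSC(=S)C1=C(Nc2ccc(Cl)cc2)CC(C)(C)CC1=O` was tested in a functional assay on PBMC cells (Homo sapiens) for inhibition, read by ELISA, with a stated time of 18 h; a higher number here means a weaker inhibitor, a lower number a stronger inhibitor. In this assay compound 1 gives only a limit, > 20 ug/mL, not a number. Compound 2 `CC1(C)CC(=O)C(C(=S)SCc2ccccc2)=C(Nc2ccc(Cl)cc2)C1` carries phenyl in place of propyl on a saturated chain carbon bound to a sulfur, and in this assay compound 2 also sits at a limit, > 20 ug/mL. Compound 3 `CC1(C)CC(=O)C(C(=S)SCCO)=C(Nc2ccc(Cl)cc2)C1` carries hydroxy in place of ethyl on a saturated chain carbon, two bonds along the chain from a sulfur, and in this assay compound 3 likewise reaches only a limit, > 20 ug/mL. Because all three values sit at the limit of > 20 ug/mL in this assay, at which 3 of the 3 values shown sit, the steps a step that the two limits leave unreadable from compound 1 to compound 2, a step that the two limits leave unreadable from compound 1 to compound 3 and a step that the two limits leave unreadable from compound 2 to compound 3 cannot be sized, so nothing shows how any change on the sulfur side chain moves the readout.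

Compound 4 `CCCCSC(=S)C1=C(Nc2ccc(Br)cc2)CC(C)(C)CC1=O` keeps everything of compound 1 except the change (bromo in place of chloro on an aromatic carbon). No measured step touches this aromatic position, so the shown data give no direction for it. Since compound 1 itself is unreadable in this assay, the step from compound 1 to compound 4 is expected to be a step that the limit leaves unreadable from compound 1 to compound 4 and most likely to end at a limit again. Compound 4 is therefore estimated at 30 ug/mL, within a range from 15 ug/mL to 100 ug/mL.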

Compound 4, half-maximal inhibitory concentration: > 20 ug/mL
Compound 4: only a limit was reported (the forecaster's own chance of this, stated with the estimate: 85%); the middle value does not contradict the limit.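

In this assay compound 4 gives > 20 ug/mL, a limit and not a number. Compound 1 also stands at a limit, so no step from compound 1 to compound 4 can be read: the limit of > 20 ug/mL in this assay, at which 4 of the 4 values shown sit.

The compounds shown leave open whether any change to the sulfur side chain or the aromatic ring can give a measurable inhibition value in this assay.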